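This account rests on a few compounds, and the source may have more. Where it says the series, first, only, none or still open, it means among the compounds named here.

Measured so far:
compound 1, `COc1ccc(C2CC(c3ccccc3)=NN2C2=NC(=O)/C(=C3\C(=O)Nc4ccc(Br)cc43)S2)cc1`, 4230 nM
compound 2, `COc1ccc(C2=NN(C3=NC(=O)/C(=C4\C(=O)Nc5ccccc54)S3)C(c3ccc(OC)cc3)C2)cc1`, 100000 nM

Compound 2 has the highest of the two numbers recorded in a functional assay on cells (Leukemia cell, Homo sapiens) for cytotoxicity, read by sulforhodamine B assay, with a stated time of 48 h; on this read-out lower numbers stand for stronger inhibition of growth and higher numbers for weaker inhibition of growth. The nearest number belongs to compound 1, which in this assay gives 4230 nM, a gap well beyond the usual scatter; compound 1 and compound 2 differ in more than one place, so these two values only show where each stands, not the effect of a single change.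

Compound 3, `COc1ccc(C2=NN(C3=NC(=O)/C(=C4\C(=O)Nc5ccc(Br)cc54)S3)C(c3ccc(OC)cc3)C2)cc1`, has not been measured. It differs from compound 2 in one place: bromo in place of hydrogen on an aromatic carbon. For the measured compounds named here, no step between measured compounds isolates this change, so its size here is unknown. Since compound 1, which carries the bromo group on the same ring, gives 4230 nM, an estimated step toward lower numbers is expected from a 5.0-fold lower number from compound 2 to compound 3 (0.70 log units; beyond the scatter), although the other difference between compound 1 and compound 2 leaves its size uncertain. On this basis compound 3 is expected to give about 20000 nM, with a range from 5000 nM to 100000 nM.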

Compound 3, concentration for total growth inhibition: 62700 nM
Estimate against measurement, compound 3: 3.1-fold (0.50 log units) below, within the range that was stated.
By their numbers in this assay, from the lowest: compound 1; then compounds 3 and 2 (each within the scatter of the next).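

In this assay, for the compounds shown here, bromo in place of hydrogen on an aromatic carbon of the six-membered ring that is part of the fused system gives a 1.6-fold lower number from compound 2 to compound 3 (0.20 log units; within the scatter), so with methoxy on both outer aromatic rings, this position shows no step that can be told from the scatter. The larger step is the other one: with bromo kept in place, adding a methoxy group gives a 15-fold higher number from compound 1 to compound 3 (1.17 log units; beyond the scatter), so among these compounds the wide gap between compound 1 and compound 2 lies on the methoxy step and not on the bromo step. Nothing measured here accounts for either step.

What bromo does on the core of compound 1, where that second methoxy group is absent, stays open, since no pair shown isolates it. Also open, from the compounds shown here alone, is how this assay would read with chloro or an amine at the bromo position, or with ethoxy or a carboxylic acid in place of the methoxy group that separates compound 1 from compound 3.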